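Trimming the Amide End of Compound 2

This account rests on a few compounds, and the source may have more. Where it says the series, first, only, none or still open, it means among the compounds named here.

Going by the values given here, compound 2 `COc1cc(-c2nn(-c3cccc(NC(=O)Nc4cccc(C(F)(F)F)c4)c3)cc2-c2ccncc2)ccc1Cl` gives 7580 nM in a functional assay on UACC-257 cells (Homo sapiens) for inhibition, read by sulforhodamine B assay, with a stated time of 48 h (on this read-out lower numbers stand for higher toxicity in this test and higher numbers for lower toxicity in this test), the lowest of the two numbers measured so far; the other belongs to compound 1 `COc1cc(-c2nn(-c3cccc(NC(=O)Nc4cc(C(F)(F)F)cc(C(F)(F)F)c4)c3)cc2-c2ccncc2)ccc1Cl`, which gives 26200 nM. Among the compounds with values here, the single measured step, a 3.5-fold lower number from compound 1 to compound 2 (0.54 log units; beyond the scatter), came from putting hydrogen in place of trifluoromethyl on an aromatic carbon. Compound 3 `COc1cc(-c2nn(-c3cccc(NC(=O)c4ccccc4)c3)cc2-c2ccncc2)ccc1Cl` goes further: phenyl in place of (3-(trifluoromethyl)phenyl)amino on a carbonyl carbon. This removes both the remaining trifluoromethyl and the amino link, so the earlier step bears on it only loosely. A small change is expected, estimated as a 1.3-fold lower number from compound 2 to compound 3 (0.10 log units; within the scatter). Compound 3 is therefore expected to give 6000 nM, within a range from 2500 nM to 15000 nM.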

Compound 3, concentration lethal to 50% of the cells: > 100000 nM
Compound 3: no number, only a limit; the forecaster's own chance of this, stated with the estimate: 5%; at least 16-fold (1.22 log units) between middle value and limit.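

In this assay replacing (3-(trifluoromethyl)phenyl)amino with phenyl on the carbonyl carbon sends the number up (an at least 13-fold higher number from compound 2 to compound 3 (1.12 log units; beyond the scatter)), whereas the earlier loss of one trifluoromethyl sent it down (a 3.5-fold lower number from compound 1 to compound 2 (0.54 log units; beyond the scatter)). The end of the molecule attached to this carbonyl carbon can therefore move the number in either direction, depending on the change. Compound 3 has no exact number, only a limit of the assay: the limit of > 100000 nM in this assay, at which 1 of the 3 values shown sits.

This change removes the amino link and the last trifluoromethyl together, and the compounds shown cannot separate the two. Phenylamino on the same carbonyl carbon would keep the link without the trifluoromethyl and so tell them apart.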